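The compounds below may be only part of what the source reports. "The series", "measured", "known", "first", "only" and "open" are said of these compounds alone.

In a functional assay on HT-29 cells (Homo sapiens) for inhibition, read by luminescence and CellTiter-Glo, with a stated time of 24 h (a lower number here means that less compound is needed, a higher number that more compound is needed for the effect), compound 1 `CN1C(=S)[C@@H](NC(=O)c2nc(Cc3ccccc3)n(C)n2)COc2ccccc21` gives 2.5 nM. Among the compounds with values here, compound 2 `CC(C)Cn1nc(C(=O)N[C@H]2COc3ccccc3N(C)C2=S)nc1Cc1ccccc1` gives 1230 nM, the higher of the two numbers measured so far. Within the data shown here, the only measured step is a 490-fold higher number from compound 1 to compound 2 (2.69 log units; beyond the scatter). That step is large and lies beyond the scatter, and it is isopropyl in place of hydrogen on a saturated chain carbon bound to an aromatic nitrogen.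

Compound 3 `CC(C)CCn1nc(C(=O)N[C@H]2COc3ccccc3N(C)C2=S)nc1Cc1ccccc1` changes the same place again: isobutyl in place of isopropyl on a saturated chain carbon bound to an aromatic nitrogen. In words, this is isobutyl in place of isopropyl on a saturated chain carbon bound to an aromatic nitrogen, which also reads as isobutyl to isopentyl.

One step is thin evidence, and the data cannot show whether the number keeps rising along this series or levels off. Among the measured compounds shown here, the one step that bears on the change, a 490-fold higher number from compound 1 to compound 2 (2.69 log units; beyond the scatter), points upward, so a further rise in this assay is expected, though a much smaller one, of a size close to the scatter. The expected step is a 2.4-fold higher number from compound 2 to compound 3 (0.39 log units; beyond the scatter). Compound 3 is estimated at 3000 nM, with an expected range from 600 nM to 12000 nM.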

Compound 3, half-maximal effective concentration: 3640 nM
Compound 3: middle estimate off by 1.2-fold (0.08 log units), on the low side; low and high end bracket the measured number.
By their numbers in this assay, from the lowest: compound 1; then compound 2; then compound 3.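

Along this position in this assay, the number has not levelled off after isopropyl, as isobutyl in place of isopropyl on a saturated chain carbon bound to an aromatic nitrogen gives a further rise beyond the scatter (a 3.0-fold higher number from compound 2 to compound 3 (0.47 log units; beyond the scatter)). This modest step is much smaller than the first one (a 490-fold higher number from compound 1 to compound 2 (2.69 log units; beyond the scatter)), so most of the total change from the smallest to the largest substituent in this set (a 1500-fold higher number from compound 1 to compound 3 (3.16 log units; beyond the scatter)) is already present in compound 2. No measurement here gives a reason for the continued rise or for the smaller size of the second step.

On these data alone, three compounds define only a short stretch of this series, so it remains open whether a longer chain such as n-hexyl would raise the number again or whether the rise would stop beyond isobutyl. As far as these compounds go, it is also open how a chain ending in an amine or a carboxylic acid, or a cyclopropylmethyl group at the same place, would compare with the purely open carbon chains of compound 2 and compound 3.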